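Working notes on compound 4 and its measured neighbours

A few compounds are considered here, and "the series" means these few. Any claim that something is new, unique, unknown or untested is made for them only; others in the source may bear on it.

Measured compounds:
Compound 1, `CCCn1c(=O)[nH]c2nc(-c3ccc(S(=O)(=O)N4CCN(c5ccccc5Br)CC4)cc3)[nH]c2c1=O`, gives in an assay on CHO cells for displacement of a labelled ligand from adenosine receptor A3 (Homo sapiens), read by scintillation counting, with a stated time of 45 min, tested at 1 uM, in the presence of a further agent that is not named here (a higher number here means more inhibition at the concentration tested (going by the name of the read-out), a lower number less inhibition), a value of 20%.
Compound 2, `CCCn1c(=O)c2[nH]c(-c3ccc(S(=O)(=O)N4CCN(c5ccc(Cl)cc5)CC4)cc3)nc2n(C)c1=O`, gives in this assay a value of 39%.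
Compound 3, `CCCn1c(=O)[nH]c2nc(-c3ccc(S(=O)(=O)N4CCN(c5ccccc5Cl)CC4)cc3)[nH]c2c1=O`, gives in this assay a value of 32%.

Compound 3 stands second highest of the three numbers in this assay. Its nearest neighbour is compound 2, whose number lies within the scatter of that of compound 3, so no order between the two can be read. Among the measured compounds shown here, the furthest is compound 1, and that gap is beyond the scatter; the only single-place step in the set is a number 12 percentage points higher from compound 1 to compound 3 (beyond the scatter), chloro in place of bromo on an aromatic carbon, a modest change.

Compound 4, `CCCn1c(=O)[nH]c2nc(-c3ccc(S(=O)(=O)N4CCN(Cc5ccc(Br)c(F)c5)CC4)cc3)[nH]c2c1=O`, has not yet been measured in this assay. It differs from compound 3 by 4-bromo-3-fluorobenzyl in place of 2-chlorophenyl on an amine nitrogen in a ring.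

For the measured compounds named here, no measured step covers a change of this kind on the amine nitrogen in a ring; the one step that touches the same halogen pair at all, a number 12 percentage points higher from compound 1 to compound 3 (beyond the scatter), is modest and sits on an aromatic carbon, not on this nitrogen. The expectation therefore rests mainly on the value of compound 3 itself. For compound 4 a step of a number 2 percentage points lower from compound 3 to compound 4 (within the scatter) is expected, which is not beyond the scatter. The estimate for compound 4 in this assay is 30%, with a range from 10% to 55%.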

Compound 4, a percentage reported as inhibition, at one concentration (the size of the read-out at that concentration, not a potency): 27%
Compound 4: middle estimate off by 3 percentage points, on the high side; measured number inside the range.
By their numbers in this assay, from the lowest: compounds 1, 4, 3 and 2 (each within the scatter of the next, the first and the last beyond it).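

In this assay, among the compounds shown here, this is the first change on the amine nitrogen in a ring, and it replaces a phenyl group carrying a single halogen with a benzyl group carrying two halogens. The step to the 4-bromo-3-fluorobenzyl group from 2-chlorophenyl is a number 5 percentage points lower from compound 3 to compound 4 (within the scatter), and the step from 2-bromophenyl is a number 7 percentage points higher from compound 1 to compound 4 (within the scatter), so neither step gives a readable change, even though the two phenyl compounds themselves lie beyond the scatter of each other. On these numbers, the position accepts this benzyl group in place of either halogenated phenyl group without a readable loss or gain, but no measurement bears on what lies behind this result.

With a single benzyl group in the set, the separate contributions of the bromo and fluoro substituents and of the benzyl carbon remain unresolved. Also open, on these data alone, is whether an unsubstituted benzyl group, a longer chain between the ring nitrogen and the aromatic ring, or an amine or carboxylic acid on that ring would move the number beyond the scatter.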